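This account rests on a few compounds, and the source may have more. Where it says the series, first, only, none or still open, it means among the compounds named here.

In a functional assay on DU-145 cells (Homo sapiens) for inhibition, read by MTT assay, with a stated time of 72 h (on this read-out higher numbers stand for weaker inhibition and lower numbers for stronger inhibition), three compounds sharing one core have been measured. Compound 1 `O=C1C=C(N2CCN(c3cccc(Cl)c3)CC2)C(=O)c2ccccc21` gives 8300 nM, compound 2 `Cc1cccc(N2CCN(C3=CC(=O)c4ccccc4C3=O)CC2)c1` gives 7400 nM and compound 3 `Cc1ccccc1N1CCN(C2=CC(=O)c3ccccc3C2=O)CC1` gives 5700 nM. These three values cannot be told apart, so compound 3 stands with the other two. Compound 4 `COc1ccccc1N1CCN(C2=CC(=O)c3ccccc3C2=O)CC1` differs from compound 3 at one place, with methoxy in place of methyl on an aromatic carbon. The closest evidence is indirect. Methyl in place of chloro gave a 1.1-fold lower number from compound 1 to compound 2 (0.05 log units; within the scatter), and 2-methylphenyl in place of 3-methylphenyl gave a 1.3-fold lower number from compound 2 to compound 3 (0.11 log units; within the scatter), while the two changes together gave a 1.5-fold lower number from compound 1 to compound 3 (0.16 log units; within the scatter). None of these compounds carries methoxy, so no shift beyond the scatter is expected in either direction. The expected change is a 1.0-fold lower number from compound 3 to compound 4 (0.02 log units; within the scatter). Compound 4 is estimated at 5500 nM, with an expected range from 2200 nM to 12000 nM.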

Compound 4, half-maximal inhibitory concentration: 8000 nM
Compound 4: middle estimate off by 1.5-fold (0.16 log units), on the low side, within the range that was stated.
By their numbers in this assay, from the lowest: compounds 3, 2, 4 and 1 (each within the scatter of the next).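

Swapping methyl for methoxy on this aromatic carbon, ortho to a large group, adds an oxygen and a hydrogen-bond acceptor, yet it gives a 1.4-fold higher number from compound 3 to compound 4 (0.15 log units; within the scatter). Compound 4 also cannot be told apart from the other two compounds, with a 1.1-fold higher number from compound 2 to compound 4 (0.03 log units; within the scatter) and a 1.0-fold lower number from compound 1 to compound 4 (0.02 log units; within the scatter), so this position has now taken three different groups without a shift beyond the scatter. No available measurement bears on why this result arises. An amine or a carboxylic acid at this position might or might not shift the number beyond the scatter. From the compounds shown here alone, how methoxy behaves elsewhere on this aromatic ring also remains open.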